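Chloro replaces nitro in compound 2

The source may report more compounds than this note shows. Statements on the series, on what has been measured and on what is new or still open speak of the compounds shown alone.

For the measured compounds named here, in a functional assay on HL-60 cells (Homo sapiens) for inhibition, read by CCK-8 assay, with a stated time of 48 h, tested at 20 uM (on this read-out higher numbers stand for more inhibition of growth at the one concentration tested and lower numbers for less inhibition of growth), two compounds have numbers so far. Going by the values given here, compound 1 (`COc1ccc(Cc2nnc(NC(=O)/C(C#N)=C/c3ccccc3OS(=O)(=O)c3ccc(Cl)cc3)s2)cc1`) gives 20% and compound 2 (`N#C/C(=C\c1ccccc1OS(=O)(=O)c1ccc([N+](=O)[O-])cc1)C(=O)Nc1nnc(Cc2cccc3ccccc23)s1`) gives 18%, so compound 2 stands within the scatter of the only other measured compound.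

Compound 3 (`N#C/C(=C\c1ccccc1OS(=O)(=O)c1ccc(Cl)cc1)C(=O)Nc1nnc(Cc2cccc3ccccc23)s1`) differs from compound 2 in one place: chloro in place of nitro on an aromatic carbon. This is chloro in place of nitro on an aromatic carbon, 4-nitrophenyl to 4-chlorophenyl. Among the compounds with values here, no measured pair isolates this change, since compound 1 and compound 2 differ in more than one place. Compound 1 does carry the 4-chlorophenyl group, and its 20% offers no sign of a shift. In this assay, no step beyond the scatter is therefore expected, and the estimate for a number 2 percentage points higher from compound 2 to compound 3 (within the scatter) stays small. Compound 3 is expected at 20%, with an estimated range of 8% to 35%.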

Compound 3, percent growth inhibition at one concentration: 15%
Estimate against measurement, compound 3: 5 percentage points above; the range from low to high includes it.
By their numbers in this assay, from the lowest: compounds 3, 2 and 1 (each within the scatter of the next).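

In this assay, for the compounds shown here, the pair of compound 2 and compound 3 isolates this position for the first time: chloro in place of nitro on an aromatic carbon gives a number 3 percentage points lower from compound 2 to compound 3 (within the scatter) and so does not separate the two groups. The pair of compound 1 and compound 3, which share the 4-chlorophenyl group, adds that naphthalen-1-yl in place of 4-methoxyphenyl gives a number 5 percentage points lower from compound 1 to compound 3 (within the scatter) and does not separate those two groups either. No measurement at hand bears on why neither change shows beyond the scatter.

Going by these compounds, whether an amine or a carboxylic acid on this aromatic carbon would give a step beyond the scatter remains open. Also open, on these data alone, is whether the step from nitro to chloro would read the same with 4-methoxyphenyl in place of naphthalen-1-yl.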